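Halogen substitution in a small cytotoxicity series

The source may report more compounds than this note shows. Statements on the series, on what has been measured and on what is new or still open speak of the compounds shown alone.

Measured so far in a functional assay on T29Kt1 cells (Homo sapiens) for cytotoxicity, read by sulforhodamine B assay, with a stated time of 3 days; a higher number here means a weaker inhibitor, a lower number a stronger inhibitor:
compound 1, `OCc1cn(Cc2ccccc2)c2ccccc12`, gives 30 nM
compound 2, `OCc1cn(Cc2cccc(F)c2)c2ccccc12`, gives 20 nM
compound 3, `OCc1cn(Cc2ccc(Cl)cc2)c2ccccc12`, gives 79 nM

Two single changes from compound 1 are recorded. Fluoro in place of hydrogen, (fluoro in place of hydrogen on an aromatic carbon), gives a 1.5-fold lower number from compound 1 to compound 2 (0.18 log units; within the scatter). Chloro in place of hydrogen, (chloro in place of hydrogen on an aromatic carbon), gives a 2.6-fold higher number from compound 1 to compound 3 (0.42 log units; beyond the scatter), and compound 3 stands as the highest of the three numbers.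

Compound 4, `OCc1cn(Cc2ccc(Cl)cc2)c2ccc(F)cc12`, is not yet measured. It differs from compound 3 by fluoro in place of hydrogen on an aromatic carbon. For the measured compounds named here, this is the same kind of change as the one from compound 1 to compound 2, but not the same: there the fluoro sits meta to a large group, here it sits on a ring that is part of a fused or bridged system of two rings, meta to a fused ring and para to a fused ring. The cores of compound 3 and compound 1 differ by chloro in place of hydrogen on an aromatic carbon.

Resting on the step of a 1.5-fold lower number from compound 1 to compound 2 (0.18 log units; within the scatter) seen for compound 1 to compound 2, the step for compound 4 in this assay is expected to be a 1.3-fold lower number from compound 3 to compound 4 (0.12 log units; within the scatter). Compound 4 is thus estimated at 60 nM, within 25 nM to 160 nM.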

Compound 4, half-maximal inhibitory concentration: 80 nM
Estimate against measurement, compound 4: 1.3-fold (0.12 log units) below; low and high end bracket the measured number.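

In this assay, fluoro in place of hydrogen on an aromatic carbon gives a 1.0-fold higher number from compound 3 to compound 4 (0.01 log units; within the scatter), and the two cases do not differ beyond the scatter: the same change on two cores in this assay, a 1.5-fold lower number (0.18 log units; within the scatter) from compound 1 to compound 2 and a 1.0-fold higher number (0.01 log units; within the scatter) from compound 3 to compound 4, 1.5-fold (0.18 log units) apart, within the scatter of two such steps

On these two cores, the change therefore leaves a step within the scatter each time. This does not show that the fluoro acts alike wherever it stands, since the two cases differ in place as well as core, and two steps within the scatter give no readable effect to carry further.

Still open, on these data alone, is how the series responds to larger groups on the same aromatic carbon, such as a methoxy group or a nitrile. Also open, as far as these compounds go, is what an amine or a carboxylic acid in place of the hydroxymethyl group would give.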